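The source may hold more compounds than are shown below. What is called first, only, known or untested is meant among the compounds shown, and "the series" means these compounds.

In a functional assay on KB cells (Homo sapiens) for inhibition (a lower number here means a stronger inhibitor, a higher number a weaker inhibitor), compound 1 (`COc1ccc(Cn2c(N)nc3cc(Cl)c(Cl)cc32)cc1`) gives 45000 nM and compound 2 (`Nc1nc2cc(Cl)c(Cl)cc2n1Cc1cccc(C(F)(F)F)c1`) gives 45000 nM as well, so the two stand level. Compound 3 (`Nc1nc2cc(Cl)c(Cl)cc2n1Cc1ccc(F)cc1`) has fluoro in place of the methoxy of compound 1, on an aromatic carbon para to a large group (fluoro in place of methoxy on an aromatic carbon). Going by the values given here, no step between measured compounds is available. Since compound 2 at 45000 nM matches compound 1 with a different substituent, no step beyond the scatter is expected in this assay in either direction. The expected step is small (a 1.1-fold lower number from compound 1 to compound 3 (0.05 log units; within the scatter)). Compound 3 is estimated at 40000 nM with an expected range (15000 nM to 100000 nM).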

Compound 3, half-maximal inhibitory concentration: 70000 nM
Beside the measured number, compound 3's estimate is 1.8-fold (0.24 log units) below it; measured number inside the range.
By their numbers in this assay, from the lowest: compounds 1, 2 and 3 (each within the scatter of the next).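

In this assay, fluoro in place of methoxy on an aromatic carbon para to a large group gives a 1.6-fold higher number from compound 1 to compound 3 (0.19 log units; within the scatter). Exchanging methoxy, with its one hydrogen-bond acceptor, for fluoro, with none, therefore makes no difference beyond the usual scatter at this position. No measurement is available to explain this result.

The compounds shown leave open whether an amine or a carboxylic acid on this aromatic carbon would shift the number beyond the scatter. They also leave open how a longer chain would behave there.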